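Aryl ketone swap on a hydroxamic acid inhibitor

A few compounds are considered here, and "the series" means these few. Any claim that something is new, unique, unknown or untested is made for them only; others in the source may bear on it.

For the measured compounds named here, compound 2 (`O=C(NO)c1ccc(Cn2ccc3cc(C(=O)c4ccc(Cl)cc4)ccc32)cc1`) gives 1060 nM in an assay on isolated protein for inhibition of histone deacetylase 8 (Homo sapiens) (on this read-out higher numbers stand for weaker inhibition and lower numbers for stronger inhibition), the highest of the two numbers measured so far, with compound 1 (`COc1ccc(C(=O)c2ccc3c(ccn3Cc3ccc(C(=O)NO)cc3)c2)cc1OC`) nearest at 756 nM. The step of a 1.4-fold higher number from compound 1 to compound 2 (0.15 log units; within the scatter), 4-chlorophenyl in place of 3,4-dimethoxyphenyl on a carbonyl carbon, stays within the scatter. Compound 3 (`COc1cccc(C(=O)c2ccc3c(ccn3Cc3ccc(C(=O)NO)cc3)c2)c1`) is not yet measured; it differs from compound 2 by 3-methoxyphenyl in place of 4-chlorophenyl on a carbonyl carbon. Going by the values given here, the only measured step that bears on this change is a 1.4-fold higher number from compound 1 to compound 2 (0.15 log units; within the scatter), which exchanged one aryl group for another at the same carbonyl carbon and moved the number by less than the scatter. A methoxy-bearing phenyl on the carbonyl, as in compound 1 with 756 nM, and a chlorophenyl, as in compound 2 with 1060 nM, therefore sit at much the same level, and no step beyond the scatter is expected for compound 3 in this assay, with at most a small drift toward the number of compound 1 given a 1.4-fold higher number from compound 1 to compound 2 (0.15 log units; within the scatter). The estimated step is a 1.2-fold lower number from compound 2 to compound 3 (0.10 log units; within the scatter). Compound 3 is expected to give 850 nM, within a range of 350 nM to 2000 nM.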

Compound 3, half-maximal inhibitory concentration: 1120 nM
Estimate against measurement, compound 3: 1.3-fold (0.12 log units) below; the measured number falls inside the stated range.
By their numbers in this assay, from the lowest: compounds 1, 2 and 3 (each within the scatter of the next).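

The third aryl group extends the earlier finding at this carbonyl carbon. In this assay, 3-methoxyphenyl in place of 4-chlorophenyl gives a step within the scatter (a 1.1-fold higher number from compound 2 to compound 3 (0.02 log units; within the scatter)), so a chlorine-bearing and a methoxy-bearing phenyl are not told apart here, now with the methoxy group on a different ring position from the chlorine. The second new step adds a single-group comparison inside the methoxy series: hydrogen in place of methoxy on an aromatic carbon also stays within the scatter (a 1.5-fold higher number from compound 1 to compound 3 (0.17 log units; within the scatter)), so 3,4-dimethoxyphenyl and 3-methoxyphenyl cannot be separated either, and nothing in the data explains this flat response.

The compounds shown leave open whether a carboxylic acid or an amine on the phenyl ring, or a cyclohexyl group in place of the phenyl, would move the number beyond the scatter. They also leave open whether these aryl groups would stay equally close on other histone deacetylases, since all three numbers come from a single assay.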